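A few compounds are considered here, and "the series" means these few. Any claim that something is new, unique, unknown or untested is made for them only; others in the source may bear on it.

Series notes, read-out a functional assay on the whole organism with Rattus norvegicus as the target; a lower number here means that less compound is needed, a higher number that more compound is needed for the effect. Three measured compounds share one core. Compound 1 `CCc1c(OC)nc2nc(-c3nnco3)cn2c1C` gives only a limit in this assay, > 50 mg/kg. Compound 2 `CCc1c(OC)nc2nc(-c3nnc(C)o3)cn2c1C` gives 2 mg/kg in this assay. Compound 3 `C/C=C/c1c(OC)nc2nc(-c3nnc(C)o3)cn2c1C` likewise gives only a limit in this assay, > 50 mg/kg. For the measured compounds named here, compound 2 therefore holds the only number in the set, the other two values being limits, so it stands alone below (the limit of > 50 mg/kg in this assay, at which 2 of the 3 values shown sit).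

Two single-point steps are measured. an at least 25-fold lower number from compound 1 to compound 2 (1.39 log units; beyond the scatter), methyl in place of hydrogen on an aromatic carbon. an at least 25-fold higher number from compound 2 to compound 3 (1.39 log units; beyond the scatter), prop-1-en-1-yl in place of ethyl on an aromatic carbon. Both steps are large, and both run between a number and a limit.

Compound 4 `CCc1c(OC)nc2nc(-c3nc(C)cs3)cn2c1C` is not yet measured. (4-methyl-1,3-thiazol-2-yl in place of 5-methyl-1,3,4-oxadiazol-2-yl on an aromatic carbon). Going by the values given here, neither measured step touches this ring, so neither bears directly on the change; they show only that single changes at other positions of this core have moved the read-out between a number and the limit in both directions. No direction for the present change can be read from them. For compound 4 in this assay the expected step is a 2.0-fold higher number from compound 2 to compound 4 (0.30 log units; within the scatter), that is none beyond the scatter. The range is kept wide because of the limit of > 50 mg/kg in this assay, at which 2 of the 3 values shown sit. Compound 4 is estimated at 4 mg/kg, between 1 mg/kg and 30 mg/kg.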

Compound 4, minimum effective dose: > 50 mg/kg
Compound 4 was reported as a limit (the forecaster's own chance of this, stated with the estimate: 30%); middle value at least 12-fold (1.09 log units) from the limit.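

In this assay, 4-methyl-1,3-thiazol-2-yl in place of 5-methyl-1,3,4-oxadiazol-2-yl gives an at least 25-fold higher number from compound 2 to compound 4 (1.39 log units; beyond the scatter), so exchanging the whole ring on this aromatic carbon can cost the measurable effect, and a single swap of the ring is enough to do so. Earlier, the methyl on the oxadiazole was the only change shown to matter on this ring; compound 4 also carries a methyl on its ring, yet its value is only a limit, so within these compounds a methyl alone does not preserve a measurable effect at this position. Compound 2 remains the only compound in the series with a number, and the rest of the set gives no second number to compare it with: the limit of > 50 mg/kg in this assay, at which 3 of the 4 values shown sit.

The step between compound 1 and compound 4 cannot be read, since both values are limits. Open, from the compounds shown here alone, is whether any other ring at this position gives a number, and whether an ethyl or an amine in place of the methyl on the 1,3,4-oxadiazol-2-yl ring does so.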